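Hydroxyl returns on a rebuilt cyclohexyl amine

This account rests on a few compounds, and the source may have more. Where it says the series, first, only, none or still open, it means among the compounds named here.

Measured compounds:
compound 1 `N#Cc1cnc(NCc2cnccc2C(F)(F)F)cc1NC[C@H]1C[C@@H](O)C1` — 4200 nM
compound 2 `CO[C@H]1CC[C@H](CNc2cc(NCc3cnccc3C(F)(F)F)ncc2C#N)CC1` — > 10000 nM

In an assay on isolated protein for inhibition of protein kinase C delta type (Homo sapiens), read by TR-FRET, with a stated time of 2 h (a higher number here means a weaker inhibitor, a lower number a stronger inhibitor), compound 1 gives 4200 nM. Compound 2 stands only at a limit, > 10000 nM, so its true inhibition is not pinned down; it sits at the limit of > 10000 nM in this assay, at which 1 of the 2 values shown sits. Going by the values given here, the one measured step, an at least 2.3-fold higher number from compound 1 to compound 2 (0.37 log units; beyond the scatter), is the only guide to what a hydroxyl or methoxy group on this ring does here.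

Compound 3 `CC1(C)C[C@H](Nc2cc(NCc3cnccc3C(F)(F)F)ncc2C#N)CC[C@H]1O` is not yet measured. It differs from compound 2 by 4-hydroxy-3,3-dimethylcyclohexyl in place of (4-methoxycyclohexyl)methyl on a nitrogen on an aromatic ring. A hydroxyl donor returns, which compound 1 also carries, while the ring now sits directly on the nitrogen without the methylene spacer of compound 1 and compound 2. Since the step to compound 2 lost the hydroxyl and cost potency, a partial recovery is expected, though the shortened link leaves the direction uncertain. Compound 3 is therefore estimated at 7000 nM, in a range from 1500 nM to 30000 nM, meaning an expected step of an at least 1.4-fold lower number from compound 2 to compound 3 (0.15 log units; that floor lies within the scatter) in this assay.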

Compound 3, half-maximal inhibitory concentration: 2200 nM
The estimate for compound 3 lay 3.2-fold (0.50 log units) above the measured number; low and high end bracket the measured number.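

The change to 4-hydroxy-3,3-dimethylcyclohexyl gives an at least 4.5-fold lower number from compound 2 to compound 3 (0.65 log units; beyond the scatter) in this assay, so a six-membered carbon ring on this nitrogen does not by itself bring weak inhibition. The value for compound 2 is a limit, which makes the size of that step a floor only: the limit of > 10000 nM in this assay, at which 1 of the 3 values shown sits. Set against (3-hydroxycyclobutyl)methyl, the same group gives a 1.9-fold lower number from compound 1 to compound 3 (0.28 log units; within the scatter), so these two hydroxyl-bearing groups cannot be told apart here, although they differ in ring size and in the link to the nitrogen.

The step from the methoxy compound changes the hydroxyl, the link and the two ring methyl groups together, and the compounds shown cannot separate their shares. On these data alone, whether a primary amine in place of the hydroxyl would serve equally well also remains open.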